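The source may report more compounds than this note shows. Statements on the series, on what has been measured and on what is new or still open speak of the compounds shown alone.

Compound 1 `COC(=O)C1=C(C)NC(=O)NC1c1ccccc1` carries a phenyl on a saturated ring carbon of the shared core. In an assay for inhibition of beta-glucuronidase (Bos taurus), read by spectrophotometry, with a stated time of 30 min (a lower number here means a stronger inhibitor, a higher number a weaker inhibitor), compound 1 gives "not active" (no number reported), so no single number stands for it; on the numbers shown it is the one member of the series without a reported concentration. Two further members are measured. Compound 2 `COC(=O)C1=C(C)NC(=O)NC1c1ccc(OC)cc1` gives 59200 nM in this assay. Compound 3 `COC(=O)C1=C(C)NC(=O)NC1c1cccc(O)c1` gives 15200 nM in this assay. Both of these numbers lie in the weak region, and compound 1 returns no number at all.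

Compound 4 `COC(=O)C1=C(C)NC(=O)NC1CC(C)C` has not been measured. It differs from compound 1 in one place: isobutyl in place of phenyl on a saturated ring carbon. For the measured compounds named here, no step between two measured compounds covers this kind of change, so nothing measured sets the size of the step. Going by the values given here, the expectation is no move beyond the scatter, or a further weakening, since compound 1 gives "not active" (no number reported) and the two measured members are themselves weak. It is likely that compound 4 again returns only a limit rather than a number. Compound 4 is estimated at 150000 nM in this assay, within an expected range from 40000 nM to 600000 nM.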

Compound 4, half-maximal inhibitory concentration: 55200 nM
Compound 4: middle estimate off by 2.7-fold (0.43 log units), on the high side, within the range that was stated.
By their numbers in this assay, from the lowest: compound 3; then compounds 4 and 2 (each within the scatter of the next).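

No step can be read from compound 1 to compound 4: in this assay compound 1 gives ("not active" (no number reported)) with no number, whereas compound 4 gives (55200 nM). Nothing measured here bears on this result. The compounds shown leave open how far isobutyl in place of phenyl moves the value on the shared core.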